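From Ethyl Ester to Carboxy at the Assay Limit

The compounds below may be only part of what the source reports. "The series", "measured", "known", "first", "only" and "open" are said of these compounds alone.

In a functional assay (plasma) for inhibition, with Oryctolagus cuniculus as the target (a higher number here means that more compound is needed for the effect, a lower number that less compound is needed), compound 1 `CCOC(=O)c1c(C)cc2cnn(-c3ccc(C)c(Cl)c3)c(=O)c2c1C` gives >= 50 uM as a limit of the assay. Compound 2 `CCOC(=O)c1ccc(-n2ncc3cc(C)c(C(=O)OCC)c(C)c3c2=O)cc1` gives >= 50 uM as a limit too, so it has no exact number and stands on the limit of >= 50 uM in this assay, at which 2 of the 2 values shown sit, in this record. Compound 3 `CCOC(=O)c1c(C)cc2cnn(-c3ccc(C(=O)O)cc3)c(=O)c2c1C` has hydrogen in place of ethyl on an oxygen next to a carbonyl group, ethoxycarbonyl to carboxy (hydrogen in place of ethyl on an oxygen next to a carbonyl group). Among the measured compounds shown here, no measured step guides this change, so only a small shift towards less compound needed is expected in this assay, an estimated at least 1.2-fold lower number from compound 2 to compound 3 (0.09 log units; that floor lies within the scatter) that may stay within the scatter. For compound 3 the expected value is 40 uM with an estimated range from 10 uM to 100 uM in this assay.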

Compound 3, concentration for half-maximal effect: >= 50 uM
Compound 3: only a limit was reported; the forecaster's own chance of this, stated with the estimate: 65%; middle value at least 1.2-fold (0.09 log units) from the limit.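

Compound 3 gives >= 50 uM, again only a limit, so the steps to it from compound 1 and compound 2 cannot be read. How much of each compound this assay would actually require stays open, with all three at one limit: the limit of >= 50 uM in this assay, at which 3 of the 3 values shown sit.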